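A few compounds are considered here, and "the series" means these few. Any claim that something is new, unique, unknown or untested is made for them only; others in the source may bear on it.

Compound 1 `CC(=O)N1N=C(c2ccc(N3CCN(C)CC3)cc2)CC1c1ccc(N(C)C)cc1`: -1.9%
Compound 2 `Cc1ccc(C(=O)N2N=C(c3ccc(N4CCN(C)CC4)cc3)CC2c2ccc(N(C)C)cc2)cc1`: -0.4%
Compound 3 `CN1CCN(c2ccc(C3=NN(S(=O)(=O)C4CC4)C(c4ccc(N(C)C)cc4)C3)cc2)CC1`: 0.2%

In a functional assay on NCI-H1975 cells (Homo sapiens) for inhibition, read by sulforhodamine B assay, tested at 10 uM (a lower number here means less inhibition, a higher number more inhibition at the concentration tested (going by the name of the read-out)), compound 1 gives -1.9%, the lowest of the three numbers, yet its neighbours sit essentially on top of it: the step of a number 1.5 percentage points higher from compound 1 to compound 2 (within the scatter) and the step of a number 2.1 percentage points higher from compound 1 to compound 3 (within the scatter) are both within the scatter, as is a number 0.6 percentage points higher from compound 2 to compound 3 (within the scatter). All three compounds give, on this read-out, numbers near zero at the concentration tested.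

Compound 4 `CC(=O)N1N=C(c2ccc(-n3ccnc3)cc2)CC1c1ccc(N(C)C)cc1` has not been measured. It differs from compound 1 in one place: 1H-imidazol-1-yl in place of 4-methylpiperazin-1-yl on an aromatic carbon. Going by the values given here, none of the measured steps touches this position; every one of them changes only the group on the ring nitrogen, and all of them stayed within the scatter. There is therefore no measured guide for this change, and the only footing is that three variations of the shared core gave near-zero inhibition. On that basis compound 4 is expected to show no step beyond the scatter, a number 3.9 percentage points higher from compound 1 to compound 4 (within the scatter). The estimate for compound 4 is 2%, with a range from -10% to 15%.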

Compound 4, a percentage reported as inhibition, at one concentration (the size of the read-out at that concentration, not a potency): -2.1%
For compound 4 the middle estimate is 4.1 percentage points above the measured one; low and high end bracket the measured number.
By their numbers in this assay, from the lowest: compounds 4, 1, 2 and 3 (each within the scatter of the next).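

In this assay, putting 1H-imidazol-1-yl in place of 4-methylpiperazin-1-yl on the aromatic carbon gives a number 0.2 percentage points lower from compound 1 to compound 4 (within the scatter) and so leaves the number near zero. Going by these compounds alone, this is the first view of a change away from the ring nitrogen, and it shows that a five-membered aromatic ring and a six-membered non-aromatic ring at this position cannot be told apart on this read-out. With this pair, the substituent on the aromatic carbon joins the group on the ring nitrogen as a place where the change shown stays within the scatter.

Going by these compounds, whether a carboxylic acid or a longer amine chain at this position would give a step beyond the scatter remains open, as does whether 1H-imidazol-1-yl would do so with cyclopropylsulfonyl on the ring nitrogen. Nothing measured beyond these numbers bears on this result.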